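This account rests on a few compounds, and the source may have more. Where it says the series, first, only, none or still open, it means among the compounds named here.

Of the compounds shown here, three built on one shared core have been tested in a functional assay on OVCAR-8 cells (Homo sapiens) for cytotoxicity, read by sulforhodamine B assay, with a stated time of 48 h, tested at 1 uM; a lower number here means a stronger effect, a higher number a weaker effect of the compound at the concentration tested. Compound 1 `COc1cc(-c2cc(/C=C/C(=O)c3ccc(N)cc3)[nH]n2)cc(OC)c1OC` gives 81% there, compound 2 `COc1cc(-c2cc(/C=C/C(=O)c3ccc(Cl)c(Cl)c3)[nH]n2)cc(OC)c1OC` gives 88% and compound 3 `COc1ccc(C(=O)/C=C/c2cc(-c3cc(OC)c(OC)c(OC)c3)n[nH]2)cc1OC` gives 69%. Compound 3 thus stands lowest of the three and shows the strongest effect on the cells: the gap to it from compound 1 is a number 12 percentage points lower from compound 1 to compound 3 (beyond the scatter) and from compound 2 it is a number 19 percentage points lower from compound 2 to compound 3 (beyond the scatter), whereas the step of a number 7 percentage points higher from compound 1 to compound 2 (within the scatter) stays within the scatter.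

Compound 4 `COc1cc(-c2cc(/C=C/C(=O)c3ccc(F)c(F)c3)[nH]n2)cc(OC)c1OC` differs from compound 3 on the carbonyl carbon: 3,4-difluorophenyl in place of 3,4-dimethoxyphenyl on a carbonyl carbon. Among the compounds with values here, the step that bears most directly on this change is the one between compound 2 and compound 3, since 3,4-dichlorophenyl and 3,4-difluorophenyl are both halogen-bearing rings and compound 4 reverses the exchange of halogens for methoxy groups. That step was a number 19 percentage points lower from compound 2 to compound 3 (beyond the scatter), so a return toward the number of compound 2 is expected rather than a further drop. Compound 4 is therefore estimated at 84% in this assay, with a range from 70% to 98%. The expected step of a number 15 percentage points higher from compound 3 to compound 4 (beyond the scatter) would be a modest weakening relative to compound 3.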

Compound 4, a percentage reported as activity, at one concentration (the size of the read-out at that concentration, not a potency): 89%
Estimate against measurement, compound 4: 5 percentage points below; the measured number falls inside the stated range.
By their numbers in this assay, from the lowest: compound 3; then compounds 1, 2 and 4 (each within the scatter of the next).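

In this assay the step is a number 20 percentage points higher from compound 3 to compound 4 (beyond the scatter), so the stronger effect seen with the 3,4-dimethoxyphenyl ring on the carbonyl carbon does not carry over to 3,4-difluorophenyl, and compound 3 now stands apart from all three other compounds by steps beyond the scatter. The two halogen-bearing rings cannot be told apart here, with a number 1 percentage points higher from compound 2 to compound 4 (within the scatter) as their step, and neither can the 3,4-difluorophenyl and 4-aminophenyl rings, with a number 8 percentage points higher from compound 1 to compound 4 (within the scatter) as theirs, so only the 3,4-dimethoxyphenyl ring separates from the others at this position. Nothing available explains why this one ring differs from the other three.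

Within the data shown here, with only one oxygen-bearing ring among the four compounds, it remains open whether both methoxy groups are needed for the stronger effect, or whether a ring carrying a single methoxy group, a hydroxyl group or an ethoxy group would match it. Since every number comes from one concentration, the compounds shown also leave open how their potencies compare.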